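Adenosine A3 displacement: pyrazolyl in place of pyridyl

A few compounds are considered here, and "the series" means these few. Any claim that something is new, unique, unknown or untested is made for them only; others in the source may bear on it.

Measured compounds:
compound 1 `CC(C)(C)Cc1c(-c2ccncc2)sc(N)c1C(=O)c1ccc(Cl)cc1`: 6%
compound 2 `CC(C)(C)Cc1c(Br)sc(N)c1C(=O)c1cccc(Cl)c1`: 1%

In an assay on CHO cells for displacement of a labelled ligand from adenosine receptor A3 (Homo sapiens), read by scintillation counting, tested at 10 uM (on this read-out lower numbers stand for less inhibition and higher numbers for more inhibition at the one concentration tested (going by the name of the read-out)), compound 1 gives 6%, the higher of the two numbers recorded so far. Compound 2 gives 1% in this assay, and the gap to compound 1 lies within the scatter of repeated measurements, so the two numbers cannot be put in order; both sit at the low end of the read-out. Within the data shown here, compound 2 also differs from compound 1 in more than one place, so no single step between measured compounds can be drawn from the pair.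

Compound 3 `CC(C)(C)Cc1c(-c2cn[nH]c2)sc(N)c1C(=O)c1ccc(Cl)cc1` is the next member to be measured. Relative to compound 1 the change is 1H-pyrazol-4-yl in place of pyridin-4-yl on an aromatic carbon.

Among the measured compounds shown here, with no step available between measured compounds, the expectation for compound 3 can rest only on the low level of compound 1 at 6% and compound 2 at 1%. The step of no change at the digits printed from compound 1 to compound 3 (within the scatter) is therefore expected to be small and not beyond the scatter, in either direction. Compound 3 is estimated at 6% in this assay, within a range of -5% to 20%.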

Compound 3, a percentage reported as inhibition, at one concentration (the size of the read-out at that concentration, not a potency): 1%
The estimate for compound 3 lay 5 percentage points above the measured number, and the stated range covers the measured number.
By their numbers in this assay, from the lowest: compounds 2, 3 and 1 (each within the scatter of the next).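

In this assay, among these compounds, the first step between compounds that differ in one place is a number 5 percentage points lower from compound 1 to compound 3 (within the scatter), so 1H-pyrazol-4-yl in place of pyridin-4-yl, on the aromatic carbon next to the ring sulfur, does not separate the two compounds on this read-out. The change exchanges a six-membered aromatic ring with 1 hetero atom for a five-membered aromatic ring with 2 hetero atoms and adds 1 hydrogen-bond donor, yet compound 3 at 1% sits at the low end of the read-out, as compound 1 does. No measurement here speaks to what lies behind this result.

Still open, as far as these compounds go, is whether any group at this carbon lifts the number clear of the low end, for instance a morpholine, a carboxylic acid or a simple methoxy group in place of the aromatic rings. From the compounds shown here alone, with both numbers this low at the one concentration tested, it also remains unknown whether the same exchange would register on a compound with a higher number, such as one carrying a cyclohexyl group where the core of compound 1 carries neopentyl.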